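Cytotoxicity notes: ring stereocentre inversion in compound 3

The source may report more compounds than this note shows. Statements on the series, on what has been measured and on what is new or still open speak of the compounds shown alone.

Among the compounds with values here, compound 2 `Cc1ccc(O)c(C(=O)NCCCN2[C@@H](C)CC[C@@H]3CCCC[C@@H]32)c1` stands at a limit on the numbers so far: in a functional assay on MDBK cells (Bos taurus) for cytotoxicity (on this read-out lower numbers stand for higher toxicity in this test and higher numbers for lower toxicity in this test), compound 2 gives > 100 ug/mL, which is a limit of the test and not a number. Compound 1 `Cc1ccc(O)c(C(=O)NCCCN2CCC[C@@H]3CCCC[C@@H]32)c1` gives > 100 ug/mL, also a limit. The step that the two limits leave unreadable from compound 1 to compound 2 is therefore not readable, and the limit of > 100 ug/mL in this assay, at which 2 of the 2 values shown sit, covers both values. Compound 3 `Cc1ccc(O)c(C(=O)NCCCN2[C@@H]3CCCC[C@H]3CC[C@@H]2C)c1` differs from compound 2 in the two compounds have the same atoms and bonds and differ only in configuration as drawn: 1 of 3 stereo elements differ; a stereocentre at a saturated ring carbon is drawn S in compound 2 and R in compound 3. Within the data shown here, no measured step touches a change of configuration, and the one known step cannot be sized, so no shift beyond the scatter is expected. The step is expected to be a step that the limit leaves unreadable from compound 2 to compound 3. Compound 3 is estimated at 150 ug/mL, within 80 ug/mL to 300 ug/mL.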

Compound 3, half-maximal cytotoxic concentration: 30 ug/mL
Estimate against measurement, compound 3: 5.0-fold (0.70 log units) above, outside the stated range (below it).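

Inverting one stereocentre at a saturated ring carbon gives, in this assay, an at least 3.3-fold lower number from compound 2 to compound 3 (0.52 log units; beyond the scatter), the first step in the series that can be read. With the atoms and bonds unchanged, this toxicity shift traces to configuration at this position alone: the fact that compounds 2 and 3 differ only in the configuration as drawn. The earlier step cannot be read, as both of its values are limits of the test: the limit of > 100 ug/mL in this assay, at which 2 of the 3 values shown sit.

Open, from the compounds shown here alone, is how the other two stereo elements count, and whether the inversion reads the same without the methyl. Also open, going by these compounds, is how a carboxylic acid on the shared core would read in this assay.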